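The compounds below may be only part of what the source reports. "The series", "measured", "known", "first", "only" and "open" are said of these compounds alone.

Measured in an ADME assay, at pH 3; on this read-out lower numbers stand for a shorter-lived compound and higher numbers for a longer-lived compound:
- compound 1 `COc1ccnc(C[S+]([O-])c2nc3cc(OC(F)F)ccc3[nH]2)c1`: 0.117 h
- compound 2 `COc1ccnc(C[S+]([O-])c2nc3cc(OCC(F)(F)F)ccc3[nH]2)c1OC`: 0.183 h
- compound 3 `COc1ccnc(C[S+]([O-])c2nc3cc(OC(F)(F)C(F)F)ccc3[nH]2)c1OC`: 0.3 h

In this assay, compound 3 stands level with compound 2 within the usual scatter, and its value lies beyond the scatter from that of compound 1. The next compound is compound 4 `COc1ccnc(C[S+]([O-])c2nc3cc(OC(F)(F)C(F)F)ccc3[nH]2)c1`, and the change is hydrogen in place of methoxy on an aromatic carbon.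

For the measured compounds named here, no measured step isolates this change. Going by the values given here, the only single-place step, a 1.6-fold higher number from compound 2 to compound 3 (0.21 log units; within the scatter), concerns the fluorinated group on the oxygen and stays within the scatter, so it suggests only that this group need not move the number much. The nearest evidence is compound 1, which also has hydrogen in place of methoxy but carries difluoromethoxy instead of the tetrafluoroethyl ether, and it gives 0.117 h. Against this, compound 3 gives 0.3 h. That gap spans two changes and cannot be divided between them, so it points only loosely towards a lower number. A modest fall is therefore expected, one that may not clearly leave the scatter. The expected move is a 1.8-fold lower number from compound 3 to compound 4 (0.25 log units; within the scatter). The estimate for compound 4 is 0.17 h, with an expected range of 0.09 h to 0.32 h.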

Compound 4, half-life in the ADME assay: 0.167 h
Estimate against measurement, compound 4: 1.0-fold (0.01 log units) above; the range from low to high includes it.
By their numbers in the ADME assay, from the lowest: compounds 1, 4, 2 and 3 (each within the scatter of the next, the first and the last beyond it).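

In the ADME assay, hydrogen in place of methoxy on this aromatic carbon, two atoms from the ring nitrogen, is now read directly as a 1.8-fold lower number from compound 3 to compound 4 (0.25 log units; within the scatter), so on its own this change does not separate the two compounds. The second new step, a 1.4-fold higher number from compound 1 to compound 4 (0.15 log units; within the scatter), also stays inside the scatter, which means the gap beyond the scatter between compound 1 and compound 3 is made up of two steps, neither of which clears the scatter alone. The same change does register in a physicochemical assay for acid dissociation, where compound 3 gives 3.86 and compound 4 gives 4.25 so that the proton is given up less readily with hydrogen at this place than with methoxy: the measured acid dissociation constant of compound 3, 3.86, and of compound 4, 4.25, a number 0.39 log units higher (beyond the scatter).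

This single pair cannot tell whether the acid dissociation constant and the half-life move together at this position, as the half-life step stays within the scatter while the other does not. As far as these compounds go, how an ethoxy group, a chlorine atom or an amine on this aromatic carbon would fall on either read-out remains open, as does whether the methoxy-to-hydrogen change behaves the same way with difluoromethoxy on the core.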